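The source may hold more compounds than are shown below. What is called first, only, known or untested is meant among the compounds shown, and "the series" means these compounds.

Measured so far in a functional assay on NCI-H460 cells (Homo sapiens) for cytotoxicity, read by MTT assay, with a stated time of 72 h; on this read-out lower numbers stand for stronger inhibition and higher numbers for weaker inhibition:

compound 1 `COc1cc2c(Oc3ccc(NC(=O)c4nn(-c5ccccc5F)c(=O)c5ccccc45)cc3F)ccnc2cc1OCCCN1CCCCC1`: 160 nM
compound 2 `COc1cc2c(Oc3ccc(NC(=O)c4nn(-c5ccccc5)c(=O)c5ccccc45)cc3F)ccnc2cc1OCCCN1CCC(C)CC1`: 550 nM

Of the two numbers, compound 2 gives the higher one and compound 1 the lower one; the gap between them is beyond the scatter of this assay. Going by the values given here, compound 1 and compound 2 differ in more than one place, so no single structural step connects them, and the gap cannot be assigned to one change.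

Compound 3 `COc1cc2c(Oc3ccc(NC(=O)c4nn(-c5ccccc5F)c(=O)c5ccccc45)cc3F)ccnc2cc1OCCCN1CCC(C)CC1` differs from compound 2 in one place only: fluoro in place of hydrogen on an aromatic carbon. The same fluoro on the same ring is present in compound 1, the compound with the lower number, but compound 1 also differs from compound 2 elsewhere, so the share of the fluoro in that gap is not separable from the data in hand.

For the step from compound 2 to compound 3 a moderate lowering of the number is expected, a 1.8-fold lower number from compound 2 to compound 3 (0.26 log units; within the scatter), of a size that may or may not reach beyond the scatter. Compound 3 is accordingly estimated at 300 nM in this assay, with a range from 120 nM to 750 nM.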

Compound 3, half-maximal inhibitory concentration: 200 nM
For compound 3 the middle estimate is 1.5-fold (0.18 log units) above the measured one; measured number inside the range.
By their numbers in this assay, from the lowest: compounds 1 and 3 (each within the scatter of the next); then compound 2.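

Notes on the series: in this assay, phenyl to 2-fluorophenyl on the aromatic ring gives a 2.8-fold lower number from compound 2 to compound 3 (0.44 log units; beyond the scatter) and so isolates the fluoro in a single step, with the methyl on the saturated ring present in both compounds. With the fluoro held in place, methyl in place of hydrogen on a saturated ring carbon gives a 1.3-fold higher number from compound 1 to compound 3 (0.10 log units; within the scatter) and stays inside the usual variation of this read-out, so compound 1 and compound 3 cannot be told apart here. The data on hand offer no measurement that accounts for the size of either step.

Going by these compounds, the fluoro step rests on one pair, both members carrying the methyl, so its size on a compound without that methyl remains open. Also open, on these data alone, is whether chloro, methyl or methoxy on the same aromatic carbon, or fluoro on another carbon of that ring, would give a step of similar size, and whether an ethyl group or a hydroxyl group on the saturated ring would stay as close to compound 1 as the methyl does.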